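Removing the benzyl from a weak uracil series

A few compounds are considered here, and "the series" means these few. Any claim that something is new, unique, unknown or untested is made for them only; others in the source may bear on it.

Measured compounds, with values from a functional assay on MCF7 cells (Homo sapiens) for antiproliferative activity, read by MTT assay, with a stated time of 72 h; a lower number here means a stronger inhibitor, a higher number a weaker inhibitor:
Compound 1, `Cc1c(CC(O)COCc2ccccc2)n(COCC[Si](C)(C)C)c(=O)[nH]c1=O`, gives > 100000 nM, which is a limit of the assay rather than a number.
Compound 2, `Cc1c(CC(O)CO)n(COCC[Si](C)(C)C)c(=O)[nH]c1=O`, gives > 100000 nM, also a limit.
Compound 3, `COCn1c(CC(O)COCc2ccccc2)c(C)c(=O)[nH]c1=O`, gives > 100000 nM, again a limit.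

Compound 3 therefore stands at the ceiling of this assay, alongside the other two compounds; all three sit at the limit of > 100000 nM in this assay, at which 3 of the 3 values shown sit, so none of them is told apart from the others. The step from compound 3 to compound 4, `COCn1c(CC(O)CO)c(C)c(=O)[nH]c1=O`, is hydrogen in place of benzyl on an oxygen on a saturated carbon. The same change has been made once before, and that step, a step that the two limits leave unreadable from compound 1 to compound 2, could not be read because both ends were limits. The other step, a step that the two limits leave unreadable from compound 1 to compound 3, is equally unreadable. With nothing but limits to go on, no change in this assay beyond the scatter is expected, and compound 4 is expected to stay at the limit as well. The estimated value for compound 4 is 200000 nM, with a range from 100000 nM to 1000000 nM, which means an expected step that the limit leaves unreadable from compound 3 to compound 4 from its neighbour.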

Compound 4, half-maximal inhibitory concentration: > 100000 nM
Compound 4 was reported as a limit; the forecaster's own chance of this, stated with the estimate: 90%; the middle value is on the limit's open side.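

In this assay compound 4 gives > 100000 nM and this is a limit of the assay rather than a number. With compound 2 and compound 3 also at limits, neither step to compound 4 can be read. The compounds shown leave open whether replacing the benzyl with hydrogen changes activity at all.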